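Cytotoxicity notes: compound 1 to compound 3

The source may hold more compounds than are shown below. What is called first, only, known or untested is meant among the compounds shown, and "the series" means these compounds.

compound 1 `O[C@@H](c1ccccc1)[C@H]1CO[C@H](c2ccccc2)[C@@H](C/C=C/c2ccccc2)C1` — 6060 nM
compound 2 `COc1ccc(/C=C/C[C@@H]2C[C@@H]([C@@H](O)c3ccc(OC)c(OC)c3)CO[C@H]2c2ccc(OC)c(OC)c2)cc1` — 17100 nM

In a functional assay on HeLa cells (Homo sapiens) for cytotoxicity, read by WST assay, with a stated time of 48 h (a lower number here means a stronger inhibitor, a higher number a weaker inhibitor), compound 1 gives the lowest of the two numbers measured; the nearest is compound 2 at 17100 nM, a gap beyond the scatter. Among the compounds with values here, no pair differing in a single place has been measured, so no step size is known for any change.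

Compound 3 `O[C@@H](c1ccccc1)[C@H]1CO[C@H](c2ccccc2)[C@@H](C/C=C/C2CCCC2)C1` differs from compound 1 by one replacement: cyclopentyl in place of phenyl on a double-bonded chain carbon bound to a double-bonded chain carbon. Within the data shown here, with no measured step to lean on, the expected step from compound 1 to compound 3 is small, at most a slight weakening, a 1.2-fold higher number from compound 1 to compound 3 (0.09 log units; within the scatter). Compound 3 is estimated at 7500 nM, between 3000 nM and 18000 nM.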

Compound 3, half-maximal inhibitory concentration: 9330 nM
Compound 3: middle estimate off by 1.2-fold (0.09 log units), on the low side, within the range that was stated.
By their numbers in this assay, from the lowest: compounds 1, 3 and 2 (each within the scatter of the next, the first and the last beyond it).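

Cyclopentyl in place of phenyl on a double-bonded chain carbon bound to a double-bonded chain carbon gives the first measured step in this series, a 1.5-fold higher number from compound 1 to compound 3 (0.19 log units; within the scatter), in this assay. At this place, then, a five-membered non-aromatic carbon ring reads the same as the six-membered aromatic ring, within the scatter. No supporting measurement bears on this result.

Going by these compounds, whether an amine or a carboxylic acid in place of cyclopentyl would shift the number stays open. So does the effect of a longer chain there.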